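Urea for benzyl on the ring amine nitrogen

The compounds below may be only part of what the source reports. "The series", "measured", "known", "first", "only" and "open" are said of these compounds alone.

Compound 2 `NC(=O)c1c(NC(=O)c2ccc(C(F)(F)F)cc2)sc2c1CCN(Cc1c(Cl)cccc1Cl)C2` gives in a functional assay on HeLa cells (Homo sapiens) for antiproliferative activity, with a stated time of 24 h (a higher number here means a weaker inhibitor, a lower number a stronger inhibitor), only a limit, > 50000 nM, and is one of the values that sit at the limit of > 50000 nM in this assay, at which 1 of the 3 values shown sits. Compound 1 `NC(=O)c1c(NC(=O)c2ccccc2Cl)sc2c1CCN(Cc1c(Cl)cccc1Cl)C2` gives 28800 nM in this assay, and compound 3 `NC(=O)c1c(NC(=O)c2cccc([N+](=O)[O-])c2)sc2c1CCN(Cc1c(Cl)cccc1Cl)C2` gives 46100 nM. The measured steps all vary the aryl on the carbonyl carbon: an at least 1.7-fold higher number from compound 1 to compound 2 (0.23 log units; that floor lies within the scatter) and a 1.6-fold higher number from compound 1 to compound 3 (0.20 log units; within the scatter), while an at least 1.0-fold lower number from compound 2 to compound 3 (0.03 log units; that floor lies within the scatter). Compound 4 `NC(=O)c1c(NC(=O)c2ccc(C(F)(F)F)cc2)sc2c1CCN(C(=O)Nc1ccccc1Cl)C2` keeps the 4-(trifluoromethyl)phenyl amide and changes the other end: (2-chlorophenyl)carbamoyl in place of 2,6-dichlorobenzyl on an amine nitrogen in a ring. Within the data shown here, none of the measured steps touches the ring amine nitrogen, so no measured step bears on this change. In this assay the expected step is a number no higher from compound 2 to compound 4 (the limit leaves the size open), most likely a limit again. The estimate for compound 4 is 50000 nM, range 15000 nM to 150000 nM.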

Compound 4, half-maximal inhibitory concentration: > 50000 nM
Compound 4: no number, only a limit; the forecaster's own chance of this, stated with the estimate: 60%; the middle value lies on the limit itself.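

In this assay, compound 2 and compound 4 both give only a limit, so no step can be read between them: the limit of > 50000 nM in this assay, at which 2 of the 4 values shown sit.

The compounds shown leave open how (2-chlorophenyl)carbamoyl compares with 2,6-dichlorobenzyl on an amine nitrogen in a ring.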